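A few compounds are considered here, and "the series" means these few. Any claim that something is new, unique, unknown or untested is made for them only; others in the source may bear on it.

In a functional assay on PC-3 cells (Homo sapiens) for cytotoxicity, read by MTT assay, with a stated time of 72 h (a higher number here means a weaker inhibitor, a lower number a stronger inhibitor), compound 3 `CNC(=O)c1cc(Oc2ccc(C3=NN(C(N)=S)C(c4ccc(F)cc4)C3)cc2)ccn1` stands at > 50000 nM, which is a limit and not a number. Compound 1 `CNC(=O)c1cc(Oc2ccc(C3=NNC(c4ccc([N+](=O)[O-])cc4)C3)cc2)ccn1` shows > 50000 nM, again a limit. Compound 2 `CNC(=O)c1cc(Oc2ccc(C3=NNC(c4ccc(F)cc4)C3)cc2)ccn1` gives a true reading of 6770 nM. The next structure, compound 4 `CNC(=O)c1cc(Oc2ccc(C3=NN(C(N)=S)C(c4cccc(Cl)c4Cl)C3)cc2)ccn1`, carries 2,3-dichlorophenyl in place of 4-fluorophenyl on a saturated ring carbon. For the measured compounds named here, two measured steps bear on this change. Swapping a substituent on that aromatic group gave an at least 7.3-fold lower number from compound 1 to compound 2 (0.86 log units; beyond the scatter), so such a swap can matter. Adding a group on an amine nitrogen in a ring gave an at least 7.3-fold higher number from compound 2 to compound 3 (0.86 log units; beyond the scatter), and compound 4 keeps that group. No step beyond the scatter is therefore expected, and the estimated change is an at least 1.2-fold lower number from compound 3 to compound 4 (0.09 log units; that floor lies within the scatter). Compound 4 is estimated at 40000 nM, with an expected range of 10000 nM to 50000 nM.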

Compound 4, half-maximal inhibitory concentration: 15900 nM
Estimate against measurement, compound 4: 2.5-fold (0.40 log units) above, and the stated range covers the measured number.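

In this assay the aromatic group on the saturated ring carbon still matters when the group of 3 heavy atoms sits on the ring nitrogen: 2,3-dichlorophenyl in place of 4-fluorophenyl gives an at least 3.1-fold lower number from compound 3 to compound 4 (0.49 log units; beyond the scatter) here. Compound 4 is the only compound shown with that nitrogen group to give a true reading. The step is only a floor, because compound 3 stands at a limit: the limit of > 50000 nM in this assay, at which 2 of the 4 values shown sit.

As far as these compounds go, it stays open how a phenyl ring carrying a single chlorine or a methoxy group would read with the same nitrogen group. Also open, from the compounds shown here alone, is how 2,3-dichlorophenyl would read with a hydrogen on that nitrogen, as in compound 2.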